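Cinnamamide series: trimethoxyphenyl to methoxyphenyl on the chain

The compounds below may be only part of what the source reports. "The series", "measured", "known", "first", "only" and "open" are said of these compounds alone.

Measured compounds:
compound 1 `COc1cccc(/C=C/C(=O)Nc2cc(OC)c(OC)c(OC)c2)c1`, 2100 nM
compound 2 `COc1ccc(C(=O)c2cc(OC)c(OC)c(OC)c2)cc1NC(=O)/C=C/c1cc(OC)c(OC)c(OC)c1`, 3900 nM
compound 3 `COc1cc(C(=O)c2cc(OC)c(OC)c(OC)c2)cc(NC(=O)/C=C/c2cc(OC)c(OC)c(OC)c2)c1OC`, 4800 nM

In a functional assay on PC-3 cells (Homo sapiens) for cytotoxicity, read by MTT assay, with a stated time of 72 h (on this read-out higher numbers stand for weaker inhibition and lower numbers for stronger inhibition), compound 3 gives 4800 nM. Compound 2 gives 3900 nM; the step of a 1.2-fold higher number from compound 2 to compound 3 (0.09 log units; within the scatter) lies within the scatter, so the two compounds cannot be ordered. Among the compounds with values here, compound 1 gives 2100 nM, the only number clearly apart from compound 3 on this read-out.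

Compound 4 `COc1cccc(/C=C/C(=O)Nc2cc(C(=O)c3cc(OC)c(OC)c(OC)c3)cc(OC)c2OC)c1` differs from compound 3 by 3-methoxyphenyl in place of 3,4,5-trimethoxyphenyl on a double-bonded chain carbon bound to a double-bonded chain carbon. Within the data shown here, no measured step covers this change: the one measured step, from compound 2 to compound 3, concerns a methoxy on the other aromatic ring and is within the scatter. Compound 1 carries the same 3-methoxyphenyl as compound 4 on the chain, but also lacks the benzoyl, so its value bears on compound 4 only loosely. Among the measured compounds shown here, with no step of size beyond the scatter among the measured compounds, no change beyond the scatter is expected in this assay, and the step of a 1.2-fold lower number from compound 3 to compound 4 (0.08 log units; within the scatter) is estimated to stay close to the value of compound 3. Compound 4 is therefore expected to give about 4000 nM, within 1500 nM to 10000 nM.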

Compound 4, half-maximal inhibitory concentration: 13300 nM
For compound 4 the middle estimate is 3.3-fold (0.52 log units) below the measured one, and the stated range ends below it.
By their numbers in this assay, from the lowest: compounds 1, 2 and 3 (each within the scatter of the next, the first and the last beyond it); then compound 4.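

In this assay, within the data shown here, the chain position gives the first step that lies beyond the scatter (from 3,4,5-trimethoxyphenyl to 3-methoxyphenyl): a 2.8-fold higher number from compound 3 to compound 4 (0.44 log units; beyond the scatter). The only earlier step (a 1.2-fold higher number from compound 2 to compound 3 (0.09 log units; within the scatter)) concerned a methoxy on the other aromatic ring and could not order its two compounds, so this chain position is the first place shown where a change separates two compounds, with 3-methoxyphenyl giving the weaker inhibition. No measurement on hand accounts for this step.

Open, from the compounds shown here alone, is whether the loss follows from the methoxy groups that leave or from the pattern of the one that stays, as a single pair cannot separate the two. Also open, going by these compounds, is how a phenyl carrying an amine or a carboxylic acid would read at this position.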